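Methoxy for chloro on a salicylhydrazone: expected cytotoxicity

A few compounds are considered here, and "the series" means these few. Any claim that something is new, unique, unknown or untested is made for them only; others in the source may bear on it.

Three salicylhydrazones have been examined in an ADME assay on cells (Mus musculus, strain BALB/C) for cytotoxicity, read by MTT assay, with a stated time of 24 h; a lower number here means that less compound is tolerated, a higher number that more compound is tolerated. Compound 1 `Cc1ccc(C(=O)N/N=C/c2ccc(Cl)cc2)c(O)c1` gives 116000 nM, the lowest of the three numbers. Compound 2 `Cc1ccc(C(=O)N/N=C/c2cc(Cl)cc(Cl)c2O)c(O)c1` gives 708000 nM, and compound 3 `Cc1ccc(C(=O)N/N=C/c2ccccc2[N+](=O)[O-])c(O)c1` gives 644000 nM; both stand well beyond the scatter above compound 1, compound 3 by the smaller margin and compound 2 by the larger. Compound 1 is thus the least tolerated of the three.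

Compound 4 `COc1ccc(/C=N/NC(=O)c2ccc(C)cc2O)cc1` has not yet been measured in this assay. It is derived from compound 1 by one change: methoxy in place of chloro on an aromatic carbon. Among the compounds with values here, no measured pair in this set shares that change, so its size cannot be read from the data. Since the two compounds that carry groups other than a single chloro on that ring, compound 2 and compound 3, both sit well above compound 1, the step of a 2.2-fold higher number from compound 1 to compound 4 (0.33 log units; beyond the scatter) is expected to be upward and modest, near the edge of the scatter. Compound 4 is accordingly estimated at 250000 nM, with a range from 80000 nM to 800000 nM.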

Compound 4, half-maximal cytotoxic concentration: 723000 nM
For compound 4 the middle estimate is 2.9-fold (0.46 log units) below the measured one; measured number inside the range.
By their numbers in this assay, from the lowest: compound 1; then compounds 3, 2 and 4 (each within the scatter of the next).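

In this assay, methoxy in place of chloro on an aromatic carbon, para to a large group, gives a 6.2-fold higher number from compound 1 to compound 4 (0.79 log units; beyond the scatter), a step beyond the scatter. Within the data shown here, this is the first single change measured in the set, and it shows that this position affects how much compound is tolerated, with the methoxy compound tolerated at a clearly higher concentration than the chloro compound. Nothing available explains why this exchange has that effect.

What the compounds shown leave open is whether the step is specific to methoxy or follows from losing chloro, and how an amine, a carboxylic acid or a longer chain such as ethoxy would behave at this place. As far as these compounds go, it also remains open whether the same exchange would give a similar step at another position on that ring.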